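A quinazoline-like Anilinopyrimidine Series: One Number, Two Blanks

The compounds below may be only part of what the source reports. "The series", "measured", "known", "first", "only" and "open" are said of these compounds alone.

Measured compounds:
- compound 1, `Nc1nccc(-c2cnc3ccccc3c2)n1`: "not active" (no number reported)
- compound 2, `FC(F)(F)c1ccc(Nc2nccc(-c3cnc4ccccc4c3)n2)cc1`: "not active" (no number reported)
- compound 3, `Cc1ccc(Nc2nccc(-c3c(C)nc4ccccn34)n2)cc1`: 89.4%

For the measured compounds named here, in a functional assay on K562 cells (Homo sapiens) for cytotoxicity, read by sulforhodamine B assay, with a stated time of 48 h, tested at 50 uM (on this read-out lower numbers stand for less inhibition and higher numbers for more inhibition at the one concentration tested (going by the name of the read-out)), compound 3 gives 89.4%, and it is the only compound of the three with a number at all. Compound 1 and compound 2 were each recorded without one, so compound 3 stands alone as the reference point; nothing can be said about the size of any step among the measured compounds.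

Compound 4, `Cc1nc2ccccn2c1-c1ccnc(Nc2ccc(C=O)s2)n1`, has not yet been measured. It keeps the core of compound 3 and differs only in the group on the ring nitrogen: 5-formylthiophen-2-yl in place of 4-methylphenyl on a nitrogen on an aromatic ring. A six-membered ring of carbon only is thus traded for a five-membered ring with one hetero atom carrying a formyl group. No comparable exchange exists among the measured compounds, so the direction of the step is open. The core shared by compound 3 and compound 4 is the part that sets compound 3 apart from the two blank entries, so a strong reading in this assay is expected to be retained at least in part. Compound 4 is expected to give 72%, within 40% to 95%, and the estimated step of a number 17.4 percentage points lower from compound 3 to compound 4 (beyond the scatter) is a modest drop, possibly within the scatter.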

Compound 4, a percentage reported as inhibition, at one concentration (the size of the read-out at that concentration, not a potency): 88.1%
Estimate against measurement, compound 4: 16.1 percentage points below; the measured number falls inside the stated range.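

In this assay, exchanging 4-methylphenyl for 5-formylthiophen-2-yl gives a number 1.3 percentage points lower from compound 3 to compound 4 (within the scatter), so the two readings cannot be told apart. For the compounds shown here, this is the first comparison that has numbers on both sides, and it shows that, for this pair, a six-membered ring of carbon only is not needed at this place: a five-membered aromatic ring with one hetero atom, carrying a formyl group, serves equally well. No measurement shown explains why the two groups read alike.

Going by these compounds, it remains open whether the formyl group contributes anything, and what a plain thiophen-2-yl group, or a carboxylic acid or an amine in place of the formyl group, would give. On these data alone, both readings also come from a single concentration, so how the potencies of the two compounds compare is unknown.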